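Replacing 4-methoxyphenyl in compound 2

This account rests on a few compounds, and the source may have more. Where it says the series, first, only, none or still open, it means among the compounds named here.

Measured so far in a functional assay on CNE-2 cells (Homo sapiens) for cytotoxicity, read by sulforhodamine B assay, with a stated time of 48 h; a higher number here means a weaker inhibitor, a lower number a stronger inhibitor
- compound 1 `COc1cc(/C=C/C(=O)c2ccc(N)c(-c3ccc(F)cc3)c2)ccc1O` gives 5750 nM
- compound 2 `COc1ccc(/C=C/C(=O)c2ccc(N)c(-c3ccc(F)cc3)c2)cc1` gives 1600 nM

Compound 2 at 1600 nM holds the lower of the two numbers. Compound 3 `Nc1ccc(C(=O)/C=C/c2ccc(O)c(F)c2)cc1-c1ccc(F)cc1` differs from it by one change 3-fluoro-4-hydroxyphenyl in place of 4-methoxyphenyl on a double-bonded chain carbon bound to a double-bonded chain carbon with 3-fluoro-4-hydroxyphenyl in place of 4-methoxyphenyl. Within the data shown here, the one measured step that bears on this is a 3.6-fold lower number from compound 1 to compound 2 (0.56 log units; beyond the scatter) where 4-methoxyphenyl replaced 4-hydroxy-3-methoxyphenyl. Read in reverse, that modest step points to a higher number, although no measured compound carries the entering group. The expected change is a 2.2-fold higher number from compound 2 to compound 3 (0.34 log units; beyond the scatter) by this estimate. In this assay compound 3 is estimated at 3500 nM with 1300 nM to 9500 nM as the expected range.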

Compound 3, half-maximal inhibitory concentration: 18100 nM
Beside the measured number, compound 3's estimate is 5.2-fold (0.71 log units) below it, outside the stated range (above it).
By their numbers in this assay, from the lowest: compound 2; then compound 1; then compound 3.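

The group on the double-bonded chain carbon matters more than the first pair suggested: in this assay, 3-fluoro-4-hydroxyphenyl in place of 4-methoxyphenyl gives an 11-fold higher number from compound 2 to compound 3 (1.05 log units; beyond the scatter). With the hydroxy kept, the neighbouring substituent also counts, as fluoro in place of methoxy on an aromatic carbon gives a 3.1-fold higher number from compound 1 to compound 3 (0.50 log units; beyond the scatter). Nothing available here accounts for either step.

The compounds shown leave open how much of the rise belongs to the fluoro and how much to the hydroxy, which enter together in one change. They also leave open how an amine or a chloro on that aromatic carbon would read.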